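From compound 2 to compound 3: an aryl exchange

This account rests on a few compounds, and the source may have more. Where it says the series, first, only, none or still open, it means among the compounds named here.

In an ADME assay on HepG2 cells (Homo sapiens) for cytotoxicity (on this read-out higher numbers stand for lower toxicity in this test and lower numbers for higher toxicity in this test), compound 1 `CSc1cccc(N2C(=O)CN(c3cccc(C(F)(F)F)c3)CC2C(=O)NC2CCCC2)c1` stands at 20000 nM and compound 2 `CSc1cccc(N2C(=O)CN(c3cc(C(F)(F)F)ccc3C)CC2C(=O)NC2CCCC2)c1` stands at 10000 nM so the two values lie within the scatter of each other and compound 2 is not set apart from compound 1. Going by the values given here, the only measured step is a 2.0-fold lower number from compound 1 to compound 2 (0.30 log units; within the scatter) for methyl in place of hydrogen on an aromatic carbon.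

Compound 3 `COc1cccc(N2CC(=O)N(c3cccc(SC)c3)C(C(=O)NC3CCCC3)C2)c1` carries 3-methoxyphenyl in place of 2-methyl-5-(trifluoromethyl)phenyl on an amine nitrogen in a ring while the cyclopentylcarbamoyl and 3-(methylsulfanyl)phenyl groups stay in place. Among the compounds with values here, this exchange is larger than the measured methyl step, and no measured compound carries 3-methoxyphenyl, so the evidence is thin. Within the data shown here, the one available guide is the step of a 2.0-fold lower number from compound 1 to compound 2 (0.30 log units; within the scatter) and it gives no reason to expect a large move. The expected step is a 1.8-fold higher number from compound 2 to compound 3 (0.26 log units; within the scatter) and this estimate stays within the scatter. The estimate for compound 3 is 18000 nM with an expected span from 7000 nM to 50000 nM as its range.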

Compound 3, half-maximal cytotoxic concentration: > 50000 nM
Compound 3: only a limit was reported; the forecaster's own chance of this, stated with the estimate: 35%; middle value at least 2.7-fold (0.44 log units) away from the limit.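

In this assay, going by these compounds alone, the aryl group on the ring amine nitrogen is the first place where an exchange moves the read-out beyond the scatter: an at least 5.0-fold higher number from compound 2 to compound 3 (0.69 log units; beyond the scatter), whereas the methyl change on that aryl ring gave a 2.0-fold lower number from compound 1 to compound 2 (0.30 log units; within the scatter). The shift also appears without the methyl group in the comparison, since methoxy in place of trifluoromethyl on an aromatic carbon gives an at least 2.5-fold higher number from compound 1 to compound 3 (0.39 log units; beyond the scatter), so the 2-methyl group alone does not account for the gap between compound 2 and compound 3. Both steps set only a minimum size and not a measured one, because compound 3 is reported only as a limit: the limit of > 50000 nM in this assay, at which 1 of the 3 values shown sits.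

Going by these compounds, how far compound 3 lies beyond that limit remains open, as does whether the shift follows the loss of trifluoromethyl or the entry of methoxy, and an unsubstituted phenyl group at this position would help separate the two. On these data alone, the cyclopentylcarbamoyl and 3-(methylsulfanyl)phenyl groups are constant across all three compounds, so it is also open whether an amine or a carboxylic acid at either of those places would change this read-out.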